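The source may hold more compounds than are shown below. What is called first, only, known or untested is meant among the compounds shown, and "the series" means these compounds.

Compound 1, `O=C1O[C@@H](CN2CCC(c3ccc(F)cc3)CC2)CN1c1ccc(-n2cc(-c3ccccn3)cn2)c(F)c1`, in an ADME assay on L02 cells (Homo sapiens) for cytotoxicity, read by MTT assay, with a stated time of 48 h (a higher number here means a weaker inhibitor, a lower number a stronger inhibitor), gives > 400 ug/mL, which is a limit of the assay and not a number.
Compound 2, `O=C(OC[C@H]1CN(c2ccc(-n3cc(-c4ccccn4)cn3)c(F)c2)C(=O)O1)c1ccccc1`, gives in this assay > 400 ug/mL, again a limit rather than a number.
Compound 3, `O=C1O[C@@H](Cn2ccnc2)CN1c1ccc(-n2cc(-c3ccccn3)cn2)c(F)c1`, gives in this assay 350 ug/mL.

Within the data shown here, compound 3 therefore holds the only actual number among the three; the other two values are limits, as described by the limit of > 400 ug/mL in this assay, at which 2 of the 3 values shown sit. Among the measured compounds shown here, the single measured step of this kind is an at least 1.1-fold lower number from compound 2 to compound 3 (0.05 log units; that floor lies within the scatter), and its floor lies within the usual scatter, so it shows no clear movement.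

Compound 4, `CONC(=O)[C@H]1CN(c2ccc(-n3cc(-c4ccccn4)cn3)c(F)c2)C(=O)O1`, has not yet been measured. It differs from compound 3 by methoxycarbamoyl in place of (1H-imidazol-1-yl)methyl on a saturated ring carbon.

For the measured compounds named here, only the step from compound 2 to compound 3 bears on this change at all, and it was at most a small one at a different position on the shared core; it gives no ground to expect a shift beyond the scatter in this assay. The author therefore expects a step of a 1.1-fold higher number from compound 3 to compound 4 (0.04 log units; within the scatter), in either direction within the scatter, and estimates for compound 4 a value of 380 ug/mL, with a range from 180 ug/mL to 800 ug/mL, with a fair chance that only a limit is reported.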

Compound 4, half-maximal inhibitory concentration: > 400 ug/mL
Compound 4: a limit, no number (the forecaster's own chance of this, stated with the estimate: 55%); middle value at least 1.0-fold (0.02 log units) away from the limit.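

On this saturated ring carbon, next to the ring oxygen, methoxycarbamoyl in place of (1H-imidazol-1-yl)methyl gives an at least 1.1-fold higher number from compound 3 to compound 4 (0.05 log units; that floor lies within the scatter) in this assay, so a group with no ring and one hydrogen-bond donor can replace the five-membered aromatic ring here without a clear movement in the number. Among these compounds, the step between compound 2 and compound 4 cannot be read, as the two values are limits and fix no distance between the compounds. Compound 4 adds one more limit to the series, and the result now sits mostly at the top of the range: the limit of > 400 ug/mL in this assay, at which 3 of the 4 values shown sit.

Going by these compounds, whether a carboxylic acid or a simple amine on this same ring carbon, or a longer chain ending in such a group, would bring the number down beyond the scatter stays open. Also open, on these data alone, is how compound 1, compound 2 and compound 4 rank against one another in this assay, since compound 3 alone holds an actual number.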